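Working notes: from compound 1 to compound 3

The source may hold more compounds than are shown below. What is called first, only, known or untested is meant among the compounds shown, and "the series" means these compounds.

Compound 1 `CCOC(=O)/C=C/C=C/C=C/C=C/c1cccn1C`: > 10000 nM (a limit)
Compound 2 `CCOC(=O)/C=C/C=C/C=C/c1[nH]ccc1Cl`: > 10000 nM (a limit)
Compound 3 `CCOC(=O)/C=C/C=C/C=C/C=C/c1[nH]ccc1Cl`: not yet measured

Both measured compounds were read in a functional assay on Raji cells (Homo sapiens) for cytotoxicity, with a stated time of 72 h (a higher number here means a weaker inhibitor, a lower number a stronger inhibitor), and the data so far show (the limit of > 10000 nM in this assay, at which 2 of the 2 values shown sit). In this assay compound 1 stands at > 10000 nM, which is a limit and not a number.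

Compound 3 keeps the core of compound 1 and differs in one place: a group of 6 heavy atoms (4 carbon, 1 nitrogen, 1 chlorine; one five-membered aromatic ring with 1 hetero atom) in place of a group of 6 heavy atoms (5 carbon, 1 nitrogen; one five-membered aromatic ring with 1 hetero atom), on a double-bonded chain carbon bound to a double-bonded chain carbon. The change lies on a double-bonded chain carbon bound to a double-bonded chain carbon.

Going by the values given here, no measured step shows what this exchange does. The expectation therefore rests on compound 1 at > 10000 nM, and no change beyond the scatter is expected in this assay. The estimate amounts to a step that the limit leaves unreadable from compound 1 to compound 3. Compound 3 is expected at 12000 nM, with an estimated range of 4000 nM to 30000 nM.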

Compound 3, half-maximal inhibitory concentration: > 10000 nM
Compound 3: no number, only a limit; the forecaster's own chance of this, stated with the estimate: 70%; the middle value does not contradict the limit.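

In this assay compound 1 and compound 3 both stand as limits and not as numbers, so no step between them can be read: the limit of > 10000 nM in this assay, at which 3 of the 3 values shown sit.

The compounds shown leave open what exchanging the 1-methyl-1H-pyrrol-2-yl group does to the read-out in this assay.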